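Methyl for Hydrogen at an Aromatic Nitrogen Chain

A few compounds are considered here, and "the series" means these few. Any claim that something is new, unique, unknown or untested is made for them only; others in the source may bear on it.

Compound 1, `CCn1c(/C=C2/C(=O)Nc3ccccc32)nc2ccccc21`, in a functional assay on BT-549 cells (Homo sapiens) for cytotoxicity, read by MTT assay, with a stated time of 48 h; on this read-out higher numbers stand for weaker inhibition and lower numbers for stronger inhibition: compound 1 gives > 50000 nM, a limit of the assay rather than a number.
Compound 2, `CC(C)n1c(/C=C2/C(=O)Nc3ccccc32)nc2ccccc21`, in this assay: compound 2 gives 38900 nM.
Compound 3, `Cn1c(/C=C2/C(=O)Nc3ccc(Cl)cc32)nc2ccccc21`, in this assay: compound 3 gives 39100 nM.

Compound 4, `CCn1c(/C=C2/C(=O)Nc3ccc(Cl)cc32)nc2ccccc21`, has not yet been measured. It differs from compound 3 by methyl in place of hydrogen on a saturated chain carbon bound to an aromatic nitrogen. The same kind of change, not the same one, separates compound 1 from compound 2, namely (methyl in place of hydrogen on a saturated chain carbon bound to an aromatic nitrogen and a saturated chain carbon); there the place also carries a saturated chain carbon. That step gave an at least 1.2-fold lower number from compound 1 to compound 2 (0.10 log units; that floor lies within the scatter), with compound 1 at the limit of > 50000 nM in this assay, at which 1 of the 3 values shown sits. Compound 2 and compound 3 show numbers within the scatter of each other. The difference between the cores of compound 1 and compound 3 is not broken down here. The step is expected to be a 1.2-fold higher number from compound 3 to compound 4 (0.06 log units; within the scatter), resting on an at least 1.2-fold lower number from compound 1 to compound 2 (0.10 log units; that floor lies within the scatter), which was itself small, while the limit for compound 1 leaves its size open. Compound 4 is therefore estimated at 45000 nM, with a range from 20000 nM to 100000 nM.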

Compound 4, half-maximal inhibitory concentration: > 50000 nM
Compound 4 was reported as a limit; the forecaster's own chance of this, stated with the estimate: 40%; at least 1.1-fold (0.04 log units) between middle value and limit.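

In this assay, methyl in place of hydrogen on a saturated chain carbon bound to an aromatic nitrogen gives an at least 1.2-fold higher number from compound 3 to compound 4 (0.10 log units; that floor lies within the scatter). Set beside the earlier step on the core of compound 1, this shows only that neither floor lies beyond the scatter, and it does not show whether the change carries over from one core to the other with the same size or direction: the same change on two cores in this assay, an at least 1.2-fold lower number (0.10 log units; that floor lies within the scatter) from compound 1 to compound 2 and an at least 1.2-fold higher number (0.10 log units; that floor lies within the scatter) from compound 3 to compound 4; the limit leaves it open whether they differ The step for chloro in place of hydrogen on an aromatic carbon cannot be read, and neither methyl step has a size of its own, with several of the values resting on a limit: the limit of > 50000 nM in this assay, at which 2 of the 4 values shown sit.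

The compounds shown leave open how a longer chain on that aromatic nitrogen, or a chain ending in an amine or a carboxylic acid, would read in this assay. They also leave open whether any such group would give values clear of the limit on both cores, where the two steps could be compared in size.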